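The compounds below may be only part of what the source reports. "The series", "measured", "known", "first", "only" and "open" are said of these compounds alone.

Compound 1 `COc1cc(/C=C/C(=O)c2cccc(-n3cc(-c4ccc(Cl)cc4)[nH]c3=O)c2)cc(OC)c1OC` was tested in a functional assay on COLO 205 cells (Homo sapiens) for inhibition (a higher number here means a weaker inhibitor of growth, a lower number a stronger inhibitor of growth), where compound 1 gives 7380 nM. Two related compounds carry a hydroxyphenyl group where compound 1 carries a trimethoxyphenyl group, and so they differ from compound 1 in more than one place. Compound 2 `O=C(/C=C/c1cccc(O)c1)c1cccc(-n2cc(-c3ccccc3)[nH]c2=O)c1` gives 2010 nM in this assay. Compound 3 `O=C(/C=C/c1cccc(O)c1)c1cccc(-n2cc(-c3ccc(Cl)cc3)[nH]c2=O)c1` gives 2290 nM in this assay. Among these three numbers compound 1 has the highest, and its gap to each of the other two lies beyond the usual scatter of repeated measurements, so compound 1 is the weakest growth inhibitor of the three.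

Compound 4 `COc1cc(/C=C/C(=O)c2cccc(-n3cc(-c4ccccc4)[nH]c3=O)c2)cc(OC)c1OC` has not yet been measured. It is obtained from compound 1 by the change (hydrogen in place of chloro on an aromatic carbon). For the measured compounds named here, one measured step bears directly on this change, the opposite swap of chloro for hydrogen on an aromatic carbon, which gave a 1.1-fold higher number from compound 2 to compound 3 (0.06 log units; within the scatter). Read in reverse, that step suggests that removing the chloro alters the number only slightly, if at all. The step of a 1.1-fold lower number from compound 1 to compound 4 (0.04 log units; within the scatter) is therefore expected to stay within the scatter. For compound 4 the estimate in this assay is 6800 nM, with a likely range from 2700 nM to 17000 nM.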

Compound 4, concentration for 50% growth inhibition: 1510 nM
For compound 4 the middle estimate is 4.5-fold (0.65 log units) above the measured one, outside the stated range (below it).
By their numbers in this assay, from the lowest: compounds 4, 2 and 3 (each within the scatter of the next); then compound 1.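

Taking the chloro off the 4-chlorophenyl group gave a 4.9-fold lower number from compound 1 to compound 4 (0.69 log units; beyond the scatter) in this assay, so a change that looked silent on the earlier pair is not silent at this position on every core. The same swap of chloro and hydrogen therefore does not carry over from the core with the hydroxyphenyl group to the core with the trimethoxyphenyl group: the same change on two cores in this assay, a 1.1-fold higher number (0.06 log units; within the scatter) from compound 2 to compound 3 and a 4.9-fold higher number (0.69 log units; beyond the scatter) from compound 4 to compound 1, 4.3-fold (0.63 log units) apart, beyond the scatter of two such steps On the trimethoxyphenyl core, the compound with chloro is the weaker growth inhibitor of the pair, while on the hydroxyphenyl core the two compounds stay within the scatter of each other, a contrast that rests on these two pairs alone and is no general rule.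

The compounds shown carry only chloro or hydrogen at this place, para to a large group, so it stays open whether a fluoro, a methyl, a methoxy or an amine there would weaken growth inhibition on the trimethoxyphenyl core as chloro does. On these data alone, it also stays open how many of the three methoxy groups are needed for the contrast, which a dimethoxyphenyl or a single methoxyphenyl group on the same core could test.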